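This account rests on a few compounds, and the source may have more. Where it says the series, first, only, none or still open, it means among the compounds named here.

Working notes on the series. In a functional assay on CHO cells for agonist activity at Free fatty acid receptor 1 (Homo sapiens), read by FLIPR and calcium flux (on this read-out lower numbers stand for an effect already at smaller amounts and higher numbers for an effect only at larger amounts of compound), compound 1 `Cc1ccccc1-c1nc(C)c(COc2ccc3c(c2)OCC3CC(=O)O)s1` gives "not determined" (no result reported), that is, no result. Among the measured compounds shown here, compound 2 `Cc1ccc(-c2nc(C)c(COc3ccc4c(c3)OCC4CC(=O)O)s2)cc1` is the only member with a number: in this assay compound 2 gives 73.5 nM, so it stands alone as the reference point, with no other measured entry to set it against. Compound 3 `Cc1nc(-c2ccc(C(F)(F)F)cc2)sc1COc1ccc2c(c1)OCC2CC(=O)O` is the next member due for measurement. Relative to compound 2 it differs in one place, (trifluoromethyl in place of methyl on an aromatic carbon), with the rest of the structure untouched. For the measured compounds named here, no step between two measured compounds is available, so there is no measured precedent for how this change plays out. On that basis the expected step in this assay is a 1.3-fold lower number from compound 2 to compound 3 (0.13 log units; within the scatter), a move of a size that does not clearly exceed the usual scatter, leaning if anything toward an effect at slightly smaller amounts. Compound 3 is therefore estimated at 55 nM in this assay, with a range from 18 nM to 180 nM, the width of that range reflecting that nothing measured yet anchors the change.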

Compound 3, half-maximal effective concentration: 96.7 nM
The estimate for compound 3 lay 1.8-fold (0.25 log units) below the measured number; measured number inside the range.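

In this assay, among the compounds shown here, the exchange of 4-methylphenyl for 4-(trifluoromethyl)phenyl gives a 1.3-fold higher number from compound 2 to compound 3 (0.12 log units; within the scatter) and thus the first measured step, at the aromatic carbon para to a large group. Compound 2 and compound 3 cannot be told apart on this read-out, so at this position, in this one pair, going from one heavy atom in methyl to four in trifluoromethyl leaves no effect that can be separated from the scatter of repeated measurements. No measured data on any property of these groups accompany the result, so it offers no basis for an explanation.

The step to or from compound 1 cannot be read, so this single pair is all that speaks for the position, and it sets no pattern for the series. Open, going by these compounds, is whether other groups at the same carbon, such as an amine, a nitrile or a longer chain like ethyl, would also stay within the scatter of compound 2 or would produce a step beyond it.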